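Lengthening the Piperazine Tail Against Macrophage Tolerance

The source may hold more compounds than are shown below. What is called first, only, known or untested is meant among the compounds shown, and "the series" means these compounds.

Compound 1, `CCCCC(=O)Nc1ccc(S(=O)(=O)N(CC(N)=O)c2ccc(N(CC(N)=O)S(=O)(=O)c3ccc(OC)cc3)c3ccccc23)cc1`, in a functional assay on cells (Peritoneal macrophage, Mus musculus) for cytotoxicity, with a stated time of 24 h (a lower number here means that less compound is tolerated, a higher number that more compound is tolerated), gives only a limit, > 100000 nM. Compound 2, `COc1ccc(S(=O)(=O)N(CC(N)=O)c2ccc(N(CC(N)=O)S(=O)(=O)c3ccc(NC(=O)CCN4CCN(C(C)C)CC4)cc3)c3ccccc23)cc1`, in this assay likewise gives only a limit, > 100000 nM.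

For the measured compounds named here, compound 2 therefore stands at the limit of > 100000 nM in this assay, at which 2 of the 2 values shown sit, so the one measured change, a step that the two limits leave unreadable from compound 1 to compound 2, cannot be sized. Compound 3, `COc1ccc(S(=O)(=O)N(CC(N)=O)c2ccc(N(CC(N)=O)S(=O)(=O)c3ccc(NC(=O)CCCN4CCN(C(C)C)CC4)cc3)c3ccccc23)cc1`, carries (4-isopropylpiperazin-1-yl)methyl in place of 4-isopropylpiperazin-1-yl on a saturated chain carbon, two bonds along the chain from a carbonyl carbon. Going by the values given here, no measured step bears on such a one-carbon lengthening, and both neighbours sit at the limit, so for compound 3 the step that the limit leaves unreadable from compound 2 to compound 3 is expected to stay within the scatter. Compound 3 is thus estimated at 150000 nM, between 50000 nM and 1000000 nM, most likely reported again as a limit.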

Compound 3, half-maximal cytotoxic concentration: > 100000 nM
Compound 3 gave a limit, no number; the forecaster's own chance of this, stated with the estimate: 85%; the middle value does not contradict the limit.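

For the compounds shown here, no step among compound 1, compound 2 and compound 3 can be read, because each gives only a limit, not a number: the limit of > 100000 nM in this assay, at which 3 of the 3 values shown sit. The compounds shown leave open how much of each is tolerated in this assay and whether lengthening the chain changes that.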